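Swapping a chain end for a thioether in a lactam series

This account rests on a few compounds, and the source may have more. Where it says the series, first, only, none or still open, it means among the compounds named here.

Of the compounds shown here, two in this set have been measured in an assay on HEK293 cells for inhibition of N-acylethanolamine-hydrolyzing acid amidase (Homo sapiens), read by fluorescence, with stated times of 10 min and 50 min; a lower number here means a stronger inhibitor, a higher number a weaker inhibitor. Compound 1, with the structure `COC(=O)N1C[C@H](NC(=O)OCCCCC2CCCCC2)C1=O`, gives 7180 nM. Compound 2, with the structure `CCCCCON1C(=O)[C@@H](NC(=O)OCCCCC2CCCCC2)[C@@H]1C`, gives 387 nM, the lower of the two numbers and therefore the stronger inhibitor, with the gap to compound 1 lying beyond the usual scatter. Among the measured compounds shown here, the two structures differ in several places at once, so no single step between them can be read out.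

Compound 3, with the structure `CSCCCON1C(=O)[C@@H](NC(=O)OCCCCC2CCCCC2)[C@@H]1C`, has not yet been measured. It keeps the whole of compound 2 except for one change: methylsulfanyl in place of ethyl on a saturated chain carbon, three bonds along the chain from an oxygen on an unsaturated carbon. The chain attached through oxygen to the lactam nitrogen thus stays the same length in heavy atoms, but its outer end now carries a sulfur instead of a carbon.

For the measured compounds named here, with no comparable step among the measured pairs, the expectation rests on the close overall match to compound 2 and on the value of compound 2, 387 nM. A step of a 1.0-fold higher number from compound 2 to compound 3 (0.01 log units; within the scatter) is estimated, that is, no clear change beyond the scatter. For compound 3 the estimate in this assay is 400 nM, within a range from 150 nM to 1200 nM.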

Compound 3, half-maximal inhibitory concentration: 167 nM
The estimate for compound 3 lay 2.4-fold (0.38 log units) above the measured number; the measured number falls inside the stated range.
By their numbers in this assay, from the lowest: compound 3; then compound 2; then compound 1.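

In this assay, the outer end of the chain attached through oxygen is not a silent spot: methylsulfanyl in place of ethyl gives a 2.3-fold lower number from compound 2 to compound 3 (0.36 log units; beyond the scatter), a modest step but one that lies beyond the scatter. Among the compounds shown here, this is the first pair in the set that differs in one place only, so this step can be tied to a single change, unlike the gap between compound 1 and compound 2. The heavy-atom count of the swapped group stays the same, so a change of atom type at the chain end, with carbon replaced by sulfur and a hydrogen-bond acceptor added, is enough to move the number, though nothing measured here gives a reason for the step.

A methoxy group in the same place would show whether the shift is specific to sulfur, and an amine or a longer chain would show how much further this end of the chain can be changed. On these data alone, whether the same swap would move the number in the same direction on a different core, such as that of compound 1, also remains open.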